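From Hydroxy to Carboxy on One Aromatic Carbon

A few compounds are considered here, and "the series" means these few. Any claim that something is new, unique, unknown or untested is made for them only; others in the source may bear on it.

Of the compounds shown here, three built on a shared core have been measured in an ADME assay on WI-38 cells (Homo sapiens) for cytotoxicity, read by sulforhodamine B assay, with a stated time of 24 h; on this read-out lower numbers stand for stronger inhibition and higher numbers for weaker inhibition. Compound 1 `Cc1ccc(/N=C2\C(=O)Nc3ccc(S(=O)(=O)N4CCOCC4)cc32)cc1` gives 309000 nM, compound 2 `O=C1Nc2ccc(S(=O)(=O)N3CCOCC3)cc2/C1=N/c1ccc(O)cc1` gives 259000 nM, and compound 3 `Cc1ccc(S(=O)(=O)N/N=C2\C(=O)Nc3ccc(S(=O)(=O)N4CCOCC4)cc32)cc1` gives 261000 nM. Compound 2 therefore stands within the usual scatter of both other compounds, and the three numbers cannot be ranked.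

The next compound to be measured is compound 4 `O=C1Nc2ccc(S(=O)(=O)N3CCOCC3)cc2/C1=N/c1ccc(C(=O)O)cc1`. It keeps the rest of compound 2 but has carboxy in place of hydroxy on an aromatic carbon, para to a large group: carboxy in place of hydroxy on an aromatic carbon.

Among the compounds with values here, only one measured step bears directly on this change: a 1.2-fold lower number from compound 1 to compound 2 (0.08 log units; within the scatter), with hydroxy in place of methyl on the same aromatic carbon. That step stays within the scatter. Compound 3, which has a different attachment on the core, also gives a close number at 261000 nM. Within the data shown here, no carboxy compound has been measured yet, so this expectation rests on indirect evidence.

On this evidence, no change beyond the scatter is expected, and the estimated step is a 1.1-fold higher number from compound 2 to compound 4 (0.03 log units; within the scatter). Compound 4 is expected to give about 280000 nM, with an estimated range from 160000 nM to 480000 nM.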

Compound 4, half-maximal inhibitory concentration: 313000 nM
For compound 4 the middle estimate is 1.1-fold (0.05 log units) below the measured one; the measured number falls inside the stated range.
By their numbers in this assay, from the lowest: compounds 2, 3, 1 and 4 (each within the scatter of the next).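

In this assay, the aromatic carbon para to a large group now carries carboxy as well as hydroxy and methyl, and the new group gives a 1.2-fold higher number from compound 2 to compound 4 (0.08 log units; within the scatter) when it replaces hydroxy and a 1.0-fold higher number from compound 1 to compound 4 (0.01 log units; within the scatter) when it replaces methyl. Before this result, the only comparison at this carbon was between two small groups; now a group with more heavy atoms and a double bond outside aromatic rings also stays within the scatter, so methyl, hydroxy and carboxy cannot be ranked here in this assay. Nothing measured here offers an explanation for why these three groups give numbers that cannot be told apart.

As far as these compounds go, whether an amine, a methoxy group or a longer chain on this same aromatic carbon would give a number beyond the scatter remains open, and so the tolerance seen here cannot yet be extended to groups of other kinds. From the compounds shown here alone, it also remains open whether carboxy would behave the same way on the different attachment carried by compound 3, or with fluorine elsewhere on the aromatic ring.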